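The source may report more compounds than this note shows. Statements on the series, on what has been measured and on what is new or still open speak of the compounds shown alone.

Compound 1 `COc1cc(OC)c(Cl)c(-c2ccc3c(NC(=O)c4ccc(N5CCN(C(C)C)CC5)cc4)n[nH]c3n2)c1Cl`: 1.4 nM
Compound 2 `COc1cc(N2CCN(C)CC2)ccc1C(=O)Nc1n[nH]c2nc(-c3c(Cl)c(OC)cc(OC)c3Cl)ccc12`: 525 nM

In a functional assay on NCI-H1581 cells (Homo sapiens) for antiproliferative activity, read by CCK-8 assay, with a stated time of 72 h (a lower number here means a stronger inhibitor, a higher number a weaker inhibitor), compound 1 gives 1.4 nM, the lowest of the two numbers. Compound 2 gives 525 nM, a gap from compound 1 that is beyond the scatter. Compound 3 `COc1cc(OC)c(Cl)c(-c2ccc3c(NC(=O)c4ccc(N)cc4)n[nH]c3n2)c1Cl` differs from compound 1 by amino in place of 4-isopropylpiperazin-1-yl on an aromatic carbon. Among the compounds with values here, no step between measured compounds that differ in one place is available, so the expectation rests on the two values alone. Compound 3 is expected to give a higher number than compound 1, a step of a 14-fold higher number from compound 1 to compound 3 (1.15 log units; beyond the scatter), probably beyond the scatter. Compound 3 is estimated at 20 nM, within 3 nM to 150 nM.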

Compound 3, half-maximal inhibitory concentration: 218 nM
Estimate against measurement, compound 3: 11-fold (1.04 log units) below, and the stated range ends below it.
By their numbers in this assay, from the lowest: compound 1; then compound 3; then compound 2.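

In this assay the exchange of 4-isopropylpiperazin-1-yl for amino on the aromatic carbon gives a 160-fold higher number from compound 1 to compound 3 (2.19 log units; beyond the scatter) and this large step lies beyond the scatter. It is the first change in a single place shown here, and it reveals that the number at this position depends strongly on the group carried there. No measured evidence bearing on the reason for this step is available.

From the compounds shown here alone, whether the isopropyl group or the piperazine ring matters more remains open. An unsubstituted piperazine or a morpholine at this place could separate the two.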